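The compounds below may be only part of what the source reports. "The series", "measured", "known", "first", "only" and "open" are said of these compounds alone.

Compound 1, `CC(C)C[C@@H]1C(=O)N[C@H](C2Cc3ccccc3C2)C(=O)N1[C@@H](C(=O)NC(C)C)c1ccco1`: 6.31 nM
Compound 2, `CNC(=O)c1ccc([C@H](C(=O)NC(C)C)N2C(=O)[C@@H](C3Cc4ccccc4C3)NC(=O)[C@H]2CC(C)C)o1`: 39.8 nM
Compound 3, `CC(C)C[C@@H]1C(=O)N[C@H](C2Cc3ccccc3C2)C(=O)N1[C@@H](C(=O)NC(C)C)c1cc(Br)cs1`: 1 nM

These three compounds share one core and differ only in the group attached to the saturated chain carbon bound to an amide-type nitrogen in a ring and a carbonyl carbon. In an assay on isolated protein for binding affinity to Oxytocin receptor (Homo sapiens) (a lower number here means a stronger inhibitor, a higher number a weaker inhibitor), compound 1 stands second highest of the three numbers: the step of a 6.3-fold higher number from compound 1 to compound 2 (0.80 log units; beyond the scatter) raised the number, while the step of a 6.3-fold lower number from compound 1 to compound 3 (0.80 log units; beyond the scatter) lowered it. Compound 4, `CC(C)C[C@@H]1C(=O)N[C@H](C2Cc3ccccc3C2)C(=O)N1[C@@H](C(=O)NC(C)C)c1cccs1`, carries the change (thiophen-2-yl in place of furan-2-yl on a saturated chain carbon bound to an amide-type nitrogen in a ring and a carbonyl carbon). The measured step that bears most on this change is a 6.3-fold lower number from compound 1 to compound 3 (0.80 log units; beyond the scatter), since it also exchanges furan-2-yl for a thiophene ring. Compound 3 carries a bromine as well. How much of that step remains when only the ring is exchanged is not known. The step of a 6.3-fold higher number from compound 1 to compound 2 (0.80 log units; beyond the scatter) concerns a different change and says little here. A gain smaller than that seen for compound 3 is therefore expected in this assay, toward a lower number. Compound 4 is expected to give 3.2 nM, with a range from 1.3 nM to 8 nM. This estimate means a step of a 2.0-fold lower number from compound 1 to compound 4 (0.29 log units; within the scatter), expected to sit close to the edge of the usual scatter.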

Compound 4, inhibition constant: 6.31 nM
For compound 4 the middle estimate is 2.0-fold (0.29 log units) below the measured one, within the range that was stated.
By their numbers in this assay, from the lowest: compound 3; then compounds 1 and 4 (each within the scatter of the next); then compound 2.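

In this assay, exchanging the ring alone gives no change at the digits printed from compound 1 to compound 4 (within the scatter), so at this position these compounds do not separate furan-2-yl from thiophen-2-yl. The earlier step to compound 3 combined the ring exchange with a bromo, and these can now be read apart: hydrogen in place of bromo gives a 6.3-fold higher number from compound 3 to compound 4 (0.80 log units; beyond the scatter), so among these compounds the lower number of compound 3 goes with the bromo and not with the sulfur in the ring. The methylcarbamoyl-bearing furan of compound 2 also now has a thiophene comparison, a 6.3-fold lower number from compound 2 to compound 4 (0.80 log units; beyond the scatter), a step that matches its distance from the plain furan, although no measurement at hand explains any of these steps.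

Going by these compounds, whether a bromo on the furan-2-yl ring would go with a similar step remains open, as does whether a chloro or a methyl group could stand in for the bromo on the thiophene. On these data alone, it is also open whether a carboxylic acid or an amine in place of the methylcarbamoyl would move the number in the same direction.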